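From Bromophenoxy to Methylphenylamino at the Shared Core

The source may hold more compounds than are shown below. What is called first, only, known or untested is meant among the compounds shown, and "the series" means these compounds.

Compound 3 `CC(C)(C)NC(=O)NS(=O)(=O)c1cc(C#N)ccc1Oc1ccc(Br)cc1` gives 5310 nM in a functional assay on HEK293 cells for antagonist activity at thromboxane A2 receptor (Homo sapiens), read by fluorescence and calcium flux (on this read-out lower numbers stand for stronger inhibition and higher numbers for weaker inhibition), placing it at the upper end of the three numbers measured. Compound 2 `CC(C)(C)NC(=O)NS(=O)(=O)c1cc(C#N)ccc1Oc1ccc(F)cc1` gives 3890 nM, and the step of a 1.4-fold higher number from compound 2 to compound 3 (0.14 log units; within the scatter) stays within the scatter. Compound 1 `Cc1cccc(Oc2ccc(C#N)cc2S(=O)(=O)NC(=O)NC(C)(C)C)c1` gives 690 nM, and the step of a 7.7-fold higher number from compound 1 to compound 3 (0.89 log units; beyond the scatter) lies beyond it. Compound 4 `Cc1ccccc1Nc1ccc(C#N)cc1S(=O)(=O)NC(=O)NC(C)(C)C` is made from compound 3 by (2-methylphenyl)amino in place of 4-bromophenoxy on an aromatic carbon. The step of a 7.7-fold higher number from compound 1 to compound 3 (0.89 log units; beyond the scatter) bears on this change: in both cases a methyl-bearing ring stands against a bromine-bearing one. Among the compounds with values here, no measured pair covers an amino linker in place of oxygen, so that part is uncharted. A lower number is therefore expected, with wide uncertainty, and the expected step is a 3.5-fold lower number from compound 3 to compound 4 (0.55 log units; beyond the scatter). Compound 4 is estimated at 1500 nM, with a range from 300 nM to 8000 nM.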

Compound 4, half-maximal inhibitory concentration: 4780 nM
Compound 4: the middle estimate sits 3.2-fold (0.50 log units) below what was measured; the measured number falls inside the stated range.
By their numbers in this assay, from the lowest: compound 1; then compounds 2, 4 and 3 (each within the scatter of the next).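

In this assay, (2-methylphenyl)amino cannot be told apart from 4-bromophenoxy (a 1.1-fold lower number from compound 3 to compound 4 (0.05 log units; within the scatter)) or from 4-fluorophenoxy (a 1.2-fold higher number from compound 2 to compound 4 (0.09 log units; within the scatter)), so a methyl-bearing ring on an amino link does not restore the lower number of compound 1. That gap stays clear (a 6.9-fold higher number from compound 1 to compound 4 (0.84 log units; beyond the scatter)), yet this step changes both the linking atom and the place of the methyl. Nothing available explains this result. It remains open which of those two changes accounts for the gap. A (3-methylphenyl)amino or 2-methylphenoxy group at this position would separate them.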